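The compounds below may be only part of what the source reports. "The series", "measured", "known", "first", "only" and "open" are said of these compounds alone.

Measured in an assay on mitochondria from L6 cells (Rattus norvegicus) for activation, with a stated time of 90 min; a higher number here means that more compound is needed for the effect, a lower number that less compound is needed:
compound 1, `Fc1ccccc1Nc1nc2nonc2nc1Nc1ccccc1OC(F)(F)F`, gives 1700 nM;
compound 2, `Fc1ccccc1Nc1nc2nonc2nc1Nc1ccc(OC(F)(F)F)cc1`, gives 1300 nM;
compound 3, `Fc1ccccc1Nc1nc2nonc2nc1Nc1ccccc1C(F)(F)F`, gives 1400 nM.

Compound 1 and compound 3 share a core and differ in one place: trifluoromethyl in place of trifluoromethoxy on an aromatic carbon. That change gave a 1.2-fold lower number from compound 1 to compound 3 (0.08 log units; within the scatter). Compound 2 is built from the same atoms as compound 1, joined differently; the difference between the two cores is not broken down here. All three numbers lie within the scatter of one another, so no order among them can be read.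

Compound 4, `Fc1ccccc1Nc1nc2nonc2nc1Nc1ccc(C(F)(F)F)cc1`, has not yet been measured. It stands to compound 2 as compound 3 stands to compound 1: trifluoromethyl in place of trifluoromethoxy on an aromatic carbon. The place is not the same word for word: in compound 3 the group sits ortho to a large group, in compound 4 para to a large group, so this is the same kind of change, not the same change. Since the earlier step was a 1.2-fold lower number from compound 1 to compound 3 (0.08 log units; within the scatter), the step in this assay is expected to be of a similar size, a 1.1-fold lower number from compound 2 to compound 4 (0.03 log units; within the scatter), resting on that single precedent. Compound 4 is thus estimated at 1200 nM, most likely between 600 nM and 2400 nM.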

Compound 4, half-maximal effective concentration: 270 nM
Compound 4: middle estimate off by 4.4-fold (0.65 log units), on the high side; the whole stated range lies above it.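

In this assay, putting trifluoromethyl in place of trifluoromethoxy, para to a large group, gave a 4.8-fold lower number from compound 2 to compound 4 (0.68 log units; beyond the scatter), so on this core the change has a clear effect on the number. The same kind of change therefore did not carry over at the same size from one core to the other, and the earlier small step was a poor guide to this one: the same change on two cores in this assay, a 1.2-fold lower number (0.08 log units; within the scatter) from compound 1 to compound 3 and a 4.8-fold lower number (0.68 log units; beyond the scatter) from compound 2 to compound 4, 4.0-fold (0.60 log units) apart, beyond the scatter of two such steps This shows that, in this series, the size of the step depends on the core it is made on, but two pairs alone cannot show what in the cores sets the size, nor how the change would behave on any further core.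

The compounds shown leave open whether a smaller or different group in the same place, such as a methyl, a chlorine or a nitrile, would give a number like that of compound 4. They also leave open what an amine or a carboxylic acid there would do, and whether the fluorine on the other aromatic ring plays any part, since it stays the same throughout.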